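The compounds below may be only part of what the source reports. "The series", "measured", "known", "first", "only" and "open" are said of these compounds alone.

Compound 1 `CCCCCC(=O)OCC(C)(C)CC1=C(O)C(=O)c2ccccc2C1=O`: 169000 nM
Compound 2 `CCCCCCC(=O)OCC(C)(C)CC1=C(O)C(=O)c2ccccc2C1=O`: 99300 nM
Compound 3 `CCCCCCCC(=O)OCC(C)(C)CC1=C(O)C(=O)c2ccccc2C1=O`: > 258000 nM

All three readings come from an ADME assay on Vero cells (Chlorocebus sabaeus) for cytotoxicity, read by MTT assay; on this read-out higher numbers stand for weaker inhibition and lower numbers for stronger inhibition. Compound 3 stands at > 258000 nM, which is a limit and not a number.

Compound 4 `CCCCCCC(C)C(=O)OCC(C)(C)CC1=C(O)C(=O)c2ccccc2C1=O` differs from compound 3 by methyl in place of hydrogen on a saturated chain carbon bound to a carbonyl carbon and a saturated chain carbon.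

Among the compounds with values here, no step has been measured at this carbon. The nearest evidence comes from additions on chain carbons five or six bonds along from a carbonyl carbon. Of these, an at least 2.5-fold higher number from compound 2 to compound 3 (0.41 log units; beyond the scatter) lies beyond the scatter, while a 1.7-fold lower number from compound 1 to compound 2 (0.23 log units; within the scatter) and an at least 1.5-fold higher number from compound 1 to compound 3 (0.18 log units; that floor lies within the scatter) do not. With only these steps to go on, no step beyond the scatter is expected in this assay, and the expected step is an at least 1.1-fold lower number from compound 3 to compound 4 (0.06 log units; that floor lies within the scatter). Compound 4 is estimated at 220000 nM, with an expected range of 100000 nM to 450000 nM.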

Compound 4, half-maximal inhibitory concentration: 450 nM
For compound 4 the middle estimate is 490-fold (2.69 log units) above the measured one, and the stated range ends above it.
By their numbers in this assay, from the lowest: compound 4; then compounds 2 and 1 (each within the scatter of the next). At a limit, above all of these: compound 3.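

In this assay, methyl in place of hydrogen on a saturated chain carbon bound to a carbonyl carbon and a saturated chain carbon gives an at least 570-fold lower number from compound 3 to compound 4 (2.75 log units; beyond the scatter); this size is a floor, as compound 3 stands at a limit. Against the hexyl and pentyl groups on the carbonyl carbon, 1-methylheptyl gives a 220-fold lower number from compound 2 to compound 4 (2.34 log units; beyond the scatter) and a 380-fold lower number from compound 1 to compound 4 (2.57 log units; beyond the scatter). The size of a methyl step therefore differs sharply within this series: the same change on two cores in this assay, a 1.7-fold lower number (0.23 log units; within the scatter) from compound 1 to compound 2 and an at least 570-fold lower number (2.75 log units; beyond the scatter) from compound 3 to compound 4, at least 330-fold (2.52 log units) apart, beyond the scatter of two such steps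

From the compounds shown here alone, whether a hydroxyl group or an amine on this carbon gives a step of like size stays open. So does whether the methyl step holds on the shorter pentyl and hexyl chains.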